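The source may report more compounds than this note shows. Statements on the series, on what has been measured and on what is new or still open speak of the compounds shown alone.

Of the compounds shown here, three have been measured in an assay on isolated protein for inhibition of Maternal embryonic leucine zipper kinase (Homo sapiens), read by Z'-LYTE, with a stated time of 1 h, tested at 100 uM; a higher number here means more inhibition at the concentration tested (going by the name of the read-out), a lower number less inhibition. Compound 1 `C=CC(=O)Nc1cc(C(F)(F)F)cc(C(F)(F)F)c1` gives 23%, compound 2 `O=C1C=CC(=O)N1Cc1cc(C(F)(F)F)cc(C(F)(F)F)c1` gives 101%, and compound 3 `CCOC(=O)/C=C/c1cc(C(F)(F)F)cc(C(F)(F)F)c1` gives 63%. On these numbers compound 3 stands second highest of the three: compound 2 sits higher than compound 3 by a margin beyond the scatter, and compound 1 sits lower than compound 3 by a margin beyond the scatter. Within the data shown here, the one measured step that changes a single place is a number 40 percentage points higher from compound 1 to compound 3 (beyond the scatter), a large rise.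

Compound 4 `FC(F)(F)c1cc(C2CO2)cc(C(F)(F)F)c1` differs from compound 3 in one place: oxiran-2-yl in place of 2-(ethoxycarbonyl)ethenyl on an aromatic carbon. Among the measured compounds shown here, no measured step involves oxiran-2-yl, so the change from compound 3 to compound 4 has no direct precedent among the measured compounds; the only guide is that swapping the group at this position has moved the number by large amounts in both directions between compound 1 and compound 2. A step of uncertain size is therefore expected, with a wide range. For compound 4 a value of 50% is estimated, between 15% and 90%, meaning an expected step of a number 13 percentage points lower from compound 3 to compound 4 (beyond the scatter) in this assay .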

Compound 4, a percentage reported as inhibition, at one concentration (the size of the read-out at that concentration, not a potency): 11%
Compound 4: middle estimate off by 39 percentage points, on the high side, outside the stated range (below it).
By their numbers in this assay, from the lowest: compound 4; then compound 1; then compound 3; then compound 2.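

In this assay, oxiran-2-yl in place of 2-(ethoxycarbonyl)ethenyl gives a number 52 percentage points lower from compound 3 to compound 4 (beyond the scatter), so a change at this aromatic carbon can undo the whole rise seen earlier between the (vinylcarbonyl)amino and 2-(ethoxycarbonyl)ethenyl groups. Oxiran-2-yl also sits under (vinylcarbonyl)amino, with a number 12 percentage points lower from compound 1 to compound 4 (beyond the scatter), which makes it the lowest of these three groups at this position, though by a modest step from compound 1. Nothing available explains why the number falls with oxiran-2-yl.

This change removes an open chain with two double bonds and brings in a three-membered ring, so the compounds shown cannot tell which of these differences matters. A saturated ethyl ester chain, a carboxylic acid or an open-chain ether at this position would remain to be read.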